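A Methyl Added to a Very Potent Dichlorophenyl Sulfonamide

The compounds below may be only part of what the source reports. "The series", "measured", "known", "first", "only" and "open" are said of these compounds alone.

Within the data shown here, compound 2 `CC1CCN(C2CCN(S(=O)(=O)c3ccc(Cl)cc3Cl)CC2)CC1` provides the only number in a functional assay on DLD-1 cells (Homo sapiens) for antiproliferative activity, read by CellTiter-Glo, with a stated time of 72 h (on this read-out lower numbers stand for stronger inhibition and higher numbers for weaker inhibition), giving 1 nM. Compound 1 `CC1CCN(C2CCN(S(=O)(=O)c3cccnc3Cl)CC2)CC1` reaches only a limit of this assay, namely > 5000 nM (the limit of > 5000 nM in this assay, at which 1 of the 2 values shown sits). Among the measured compounds shown here, the single measured step, an at least 5000-fold lower number from compound 1 to compound 2 (3.69 log units; beyond the scatter), changes the group on the sulfonyl sulfur and therefore bears little on the present change. Compound 3 `Cc1cc(S(=O)(=O)N2CCC(N3CCC(C)CC3)CC2)c(Cl)cc1Cl` differs from compound 2 by methyl in place of hydrogen on an aromatic carbon. Without a comparable measured step, no movement beyond the scatter is expected, and the step of a 2.0-fold higher number from compound 2 to compound 3 (0.30 log units; within the scatter) is estimated. Compound 3 is therefore expected at 2 nM, with a range from 0.5 nM to 8 nM.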

Compound 3, half-maximal inhibitory concentration: 2 nM
For compound 3 middle estimate and measured number coincide at the digits printed; the measured number falls inside the stated range.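

In this assay, the step of a 2.0-fold higher number from compound 2 to compound 3 (0.30 log units; within the scatter) shows that methyl in place of hydrogen is accommodated on this aromatic carbon, ortho to a chloro group and para to a chloro group. On this read-out, compound 2 and compound 3 cannot be told apart, so the very strong inhibition survives the added carbon at this position. Nothing shown offers a reason for this step. On these data alone, it remains open whether an amine, a methoxy group or a longer chain on the same carbon would be accommodated as well. As far as these compounds go, it also remains open whether a methyl on another carbon of this ring would give a comparable number.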